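Methylcarbamoyl for chloro on the aryl hydrazone

The compounds below may be only part of what the source reports. "The series", "measured", "known", "first", "only" and "open" are said of these compounds alone.

Compound 1 `CC1CC/C(=N\Nc2ccc(Cl)cc2)c2ncc(C(=O)O)c(=O)n21` — 0.5 umol/kg
Compound 2 `CC1CC/C(=N\Nc2cccc(C(=O)O)c2)c2ncc(C(=O)O)c(=O)n21` — 26.6 umol/kg

Going by the values given here, in a functional assay on the whole organism for inhibition, with Rattus norvegicus as the target (a higher number here means that more compound is needed for the effect, a lower number that less compound is needed), compound 1 gives 0.5 umol/kg, the lowest of the two numbers known. In this assay compound 2 gives 26.6 umol/kg, a much higher number, and the gap between compound 1 and compound 2 lies well beyond the scatter. Compound 2 carries a carboxylic acid on the aryl ring where compound 1 carries chloro, and only these two points are known.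

Compound 3 `CNC(=O)c1ccc(N/N=C2\CCC(C)n3c2ncc(C(=O)O)c3=O)cc1` has not yet been measured in this assay. The difference from compound 1 is methylcarbamoyl in place of chloro on an aromatic carbon: the chloro leaves and a methylcarbamoyl enters, placed on an aromatic carbon of a six-membered aromatic ring of carbon only.

Among the compounds with values here, with no measured step on the same change, the account can only weigh the two known points. The entering group brings a hydrogen-bond donor and acceptor that the chloro lacked, and a neutral but larger substituent now sits where compound 2 carried its acid. The number for compound 3 is therefore expected to rise above that of compound 1, by an 8.0-fold higher number from compound 1 to compound 3 (0.90 log units; beyond the scatter), less than the distance to compound 2. Compound 3 is estimated at 4 umol/kg, within a range from 1 umol/kg to 20 umol/kg.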

Compound 3, dose for 50% inhibition: 9.6 umol/kg
Beside the measured number, compound 3's estimate is 2.4-fold (0.38 log units) below it; the range from low to high includes it.
By their numbers in this assay, from the lowest: compound 1; then compound 3; then compound 2.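

In this assay, going by these compounds alone, methylcarbamoyl in place of chloro on the aromatic carbon gives a 19-fold higher number from compound 1 to compound 3 (1.28 log units; beyond the scatter), a large step and the first change at a single place on this ring that can be read. It shows that this position is sensitive to what it carries: with the rest of compound 1 unchanged, four heavy atoms with a hydrogen-bond donor and a hydrogen-bond acceptor in place of a single chlorine are enough to raise the dose needed, and the entering group does so with no net charge. No measurement at hand bears on what lies behind this step.

The compounds shown leave open whether the amide hydrogen or the larger size of the entering group accounts for the step; a dimethylcarbamoyl or an acetyl at this place would help to separate the two. They also leave open whether any other small group, such as fluoro or methoxy, would keep the number close to that of compound 1 at 0.5 umol/kg and whether methylcarbamoyl would give the same step on another carbon of the ring.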